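The source may hold more compounds than are shown below. What is called first, only, known or untested is meant among the compounds shown, and "the series" means these compounds.

Compound 1 `O=S(=O)(Nc1ccc2oc(-c3ccccc3)nc2c1)c1cccc(C(F)(F)F)c1` was examined in an ADME assay on HEK293 cells (Homo sapiens) for cytotoxicity, read by resazurin assay, with a stated time of 48 h; a lower number here means that less compound is tolerated, a higher number that more compound is tolerated. For compound 1 the read-out is only a limit of the assay, > 100000 nM, not a number. Compound 3 `O=S(=O)(Nc1ccc2oc(-c3ccccc3)nc2c1)c1ccc(F)c(C(F)(F)F)c1` likewise gives only a limit in this assay, > 100000 nM. Compound 2 `O=S(=O)(Nc1ccc(-c2nc3ccccc3o2)cc1)c1cccc(Cl)c1` too gives only a limit, > 100000 nM. Among the measured compounds shown here, the one step between measured compounds that differ in a single place, a step that the two limits leave unreadable from compound 1 to compound 3, cannot be read because the limit of > 100000 nM in this assay, at which 3 of the 3 values shown sit, holds both of its ends, so no direction or size can be taken from it, and nothing in the data sets one compound apart from another.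

Compound 4 `O=S(=O)(Nc1ccc2oc(-c3ccccc3)nc2c1)c1cccc(O)c1` differs from compound 1 in one place: hydroxy in place of trifluoromethyl on an aromatic carbon. For the measured compounds named here, no measured step bears on a hydroxy entering or a trifluoromethyl leaving, and the only step available is unreadable, so the measured steps give no direction to expect; all three compounds simply sit at the same limit. The expectation for this assay is therefore a step that stays within the scatter, with compound 4 expected to remain at that limit, a number no higher from compound 1 to compound 4 (the limit leaves the size open). Compound 4 is estimated to give about 100000 nM in this assay, with a range from 30000 nM to 100000 nM.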

Compound 4, half-maximal cytotoxic concentration: > 100000 nM
Compound 4: no number, only a limit; the forecaster's own chance of this, stated with the estimate: 85%; the middle value sits exactly at the limit.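

Compound 4, like compound 1, gives only a limit and not a number in this assay, so no new step can be read from this result, and the change from trifluoromethyl to hydroxy has no readable size or direction: the limit of > 100000 nM in this assay, at which 4 of the 4 values shown sit.

The compounds shown leave open at what concentration any of them would become toxic to these cells, and whether any single change in structure alters that concentration.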